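Lengthening the Sulfur Chain: Expected Cytotoxicity of Compound 4

The source may hold more compounds than are shown below. What is called first, only, known or untested is meant among the compounds shown, and "the series" means these compounds.

Compound 1 `CCCCSc1nc(N)nc2c1ncn2/C=C1/CC1(CO)CO`: in an ADME assay on HFF cells (Homo sapiens) for cytotoxicity, with a stated time of 8 days (on this read-out lower numbers stand for higher toxicity in this test and higher numbers for lower toxicity in this test), compound 1 reaches only the limit > 300000 nM.
Compound 2 `Nc1nc(NCc2ccccc2)c2ncn(/C=C3/CC3(CO)CO)c2n1`: in this assay compound 2 reaches only the limit > 300000 nM.
Compound 3 `CCCSc1nc(N)nc2c1ncn2/C=C1/CC1(CO)CO`: in this assay compound 3 reaches only the limit > 300000 nM.

Compound 3 thus stands where the other two stand, at the top limit of the test rather than at a number, since every value shown sits at the limit of > 300000 nM in this assay, at which 3 of the 3 values shown sit. Compound 4 `CCCCCCSc1nc(N)nc2c1ncn2/C=C1/CC1(CO)CO` differs from compound 3 by propyl in place of hydrogen on a saturated chain carbon, three bonds along the chain from a sulfur. The step that most resembles this change, a step that the two limits leave unreadable from compound 1 to compound 3, also alters the chain on the sulfur, and the remaining steps, a step that the two limits leave unreadable from compound 1 to compound 2 and a step that the two limits leave unreadable from compound 2 to compound 3, are equally unreadable. No readable step exists, so the expectation is that compound 4 again reaches only the limit, a step of a number no higher from compound 3 to compound 4 (the limit leaves the size open). Compound 4 is estimated at 300000 nM, between 100000 nM and 1000000 nM.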

Compound 4, half-maximal cytotoxic concentration: > 300000 nM
Compound 4 was reported as a limit; the forecaster's own chance of this, stated with the estimate: 80%; the middle value lies on the limit itself.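

In this assay, for the compounds shown here, compound 4, like compound 1, compound 2 and compound 3, gives only a limit, so no step among them can be read. The compounds shown leave open whether changing the group on the shared core alters cytotoxicity at all.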